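From hydroxy to methoxy on the shared core

The compounds below may be only part of what the source reports. "The series", "measured", "known", "first", "only" and "open" are said of these compounds alone.

- Compound 1 `COc1ccc(-c2c(-c3cc(OC)c(OC)c(OC)c3)ss/c2=N/O)cc1`: > 100000 nM (a limit, not a number)
- Compound 2 `COc1ccc(-c2c(-c3cc(OC)c(OC)c(OC)c3)ss/c2=N/O)cc1N`: 2910 nM

Among the measured compounds shown here, in a functional assay on KB cells (Homo sapiens) for antiproliferative activity, read by MTT assay, with a stated time of 72 h (on this read-out higher numbers stand for weaker inhibition and lower numbers for stronger inhibition), compound 2 holds the only actual number, 2910 nM. For the measured compounds named here, the one measured step is an at least 34-fold lower number from compound 1 to compound 2 (1.53 log units; beyond the scatter), a large change made by amino in place of hydrogen on an aromatic carbon. That step lies elsewhere on the structure, so it gives no direct guide to the next change. Compound 3 `CO/N=c1/ssc(-c2cc(OC)c(OC)c(OC)c2)c1-c1ccc(OC)c(N)c1` has methyl in place of hydrogen on an oxygen, hydroxy to methoxy: methyl in place of hydrogen on an oxygen. The expected result is a 1.0-fold higher number from compound 2 to compound 3 (0.01 log units; within the scatter), so no shift beyond the scatter is expected in either direction. Compound 3 is estimated at 3000 nM, within an expected range of 600 nM to 15000 nM.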

Compound 3, half-maximal inhibitory concentration: 517 nM
Beside the measured number, compound 3's estimate is 5.8-fold (0.76 log units) above it, and the stated range ends above it.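

Methyl in place of hydrogen on an oxygen whose other neighbour is a double-bonded nitrogen gives a 5.6-fold lower number from compound 2 to compound 3 (0.75 log units; beyond the scatter), so this position also responds to change, beyond the scatter. The methoxy group and the amino group stand together in compound 3, which holds the lower of the two actual numbers. Nothing shown accounts for this step. From the compounds shown here alone, how an ethyl group or a longer chain on this oxygen would read remains open. So does whether methoxy would give a similar step on a core without the amino group.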